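The source may report more compounds than this note shows. Statements on the series, on what has been measured and on what is new or still open speak of the compounds shown alone.

Values measured in a functional assay on MCF7 cells (Homo sapiens) for antiproliferative activity, read by MTT assay, with a stated time of 24 h (on this read-out lower numbers stand for stronger inhibition and higher numbers for weaker inhibition), are as follows

Compound 1 (`CCn1c(C(=O)N[C@H](CO)CCCO)ccc1C(CC)(CC)c1ccc(OCS(=O)(=O)c2ccccc2)c(C)c1`) gives 31400 nM
Compound 2 (`CCn1c(C(=O)N[C@H](C)C(=O)O)ccc1C(CC)(CC)c1ccc(OCS(=O)(=O)c2ccccc2)c(C)c1`) gives > 50000 nM (a limit of the assay)
Compound 3 (`CCn1c(C(=O)NC2(C(=O)O)CC2)ccc1C(CC)(CC)c1ccc(OCS(=O)(=O)c2ccccc2)c(C)c1`) gives 41200 nM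

Compound 3 at 41200 nM lies within the scatter of compound 1 at 31400 nM and so cannot be ranked against it. Compound 2 has only a limit. In compound 4 (`CCn1c(C(=O)N[C@H](CCC(=O)O)C(=O)O)ccc1C(CC)(CC)c1ccc(OCS(=O)(=O)c2ccccc2)c(C)c1`), 1,3-dicarboxypropyl stands in place of 1-carboxycyclopropyl on an amide-type nitrogen (1,3-dicarboxypropyl in place of 1-carboxycyclopropyl on an amide-type nitrogen). The measured changes on this nitrogen are all small: one is a 1.3-fold higher number from compound 1 to compound 3 (0.12 log units; within the scatter) and the others, floors only, are an at least 1.2-fold lower number from compound 2 to compound 3 (0.08 log units; that floor lies within the scatter) and an at least 1.5-fold higher number from compound 1 to compound 2 (0.20 log units; that floor lies within the scatter) as well. On these steps, no change beyond the scatter is expected in this assay and the estimated move is a 1.1-fold higher number from compound 3 to compound 4 (0.04 log units; within the scatter) in size. Compound 4 may also be expected to return only a limit. The estimated value for compound 4 is 45000 nM (expected range 25000 nM to 80000 nM).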

Compound 4, half-maximal inhibitory concentration: > 50000 nM
Compound 4: no number, only a limit; the forecaster's own chance of this, stated with the estimate: 50%; at least 1.1-fold (0.04 log units) between middle value and limit.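

In this assay compound 4 gives > 50000 nM, which is a limit of the assay and not a number. Its floors, an at least 1.2-fold higher number from compound 3 to compound 4 (0.08 log units; that floor lies within the scatter) and an at least 1.5-fold higher number from compound 1 to compound 4 (0.20 log units; that floor lies within the scatter), leave 1,3-dicarboxypropyl unranked against the earlier groups on this amide-type nitrogen, and the step between the two limits cannot be read. What is new is only that compound 4 joins compound 2 at the same limit: the limit of > 50000 nM in this assay, at which 2 of the 4 values shown sit.

The compounds shown leave open whether an amine or a plain alkyl chain on this nitrogen would give a step beyond the scatter.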